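The compounds below may be only part of what the source reports. "The series", "measured", "known", "first", "only" and "open" are said of these compounds alone.

Working notes on the series, read in a functional assay on MDA-MB-468 cells (Homo sapiens) for antiproliferative activity; a lower number here means a stronger inhibitor of growth, a higher number a weaker inhibitor of growth. Compound 1 `Cc1cc(-c2nc3ccccc3s2)ccc1N` reads < 0.1 nM, which is a limit of the assay and not a number. Compound 2 `Oc1ccc(-c2nc3ccccc3s2)cc1O` gives 220 nM. Compound 3 `COc1ccc(-c2nc3cc(F)ccc3s2)cc1C` gives 58 nM, the lower of the two actual numbers, and its gap to compound 2 lies beyond the scatter.

The next compound to be measured is compound 4 `COc1ccc(-c2nc3cc(F)ccc3s2)cc1Cl`, which carries chloro in place of methyl on an aromatic carbon, ortho to a methoxy group and meta to a large group: chloro in place of methyl on an aromatic carbon. Within the data shown here, the series holds no measured step of this kind, so the expectation starts from compound 3 at 58 nM and has little else to lean on. No shift beyond the scatter is expected in this assay, and the expected 1.5-fold lower number from compound 3 to compound 4 (0.16 log units; within the scatter) is small, with a wide margin in either direction. For compound 4 the estimated value is 40 nM, with an expected range of 7 nM to 230 nM.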

Compound 4, concentration for 50% growth inhibition: 480 nM
For compound 4 the middle estimate is 12-fold (1.08 log units) below the measured one, outside the stated range (above it).
By their numbers in this assay, from the lowest: compound 3; then compound 2; then compound 4. At a limit, below all of these: compound 1.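

In this assay, chloro in place of methyl gives an 8.3-fold higher number from compound 3 to compound 4 (0.92 log units; beyond the scatter) on this aromatic carbon, ortho to a methoxy group and meta to a large group. Among these compounds, this is the only measured step at this position, and it shows that exchanging one heavy atom for another here is enough to move the number beyond the scatter, with methyl the better of the two groups. Nothing measured for these compounds accounts for the step.

On these data alone, whether other groups at this position, such as ethyl, trifluoromethyl or a nitrile, would stay close to methyl or fall with chloro remains open. Also open, as far as these compounds go, is whether the same exchange would have a similar effect on the core of compound 1 or compound 2, which differ from compound 3 in more than one place.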